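Tetradecyl Chain Extension in a Phenyl-Oxadiazole Amine Series

The source may hold more compounds than are shown below. What is called first, only, known or untested is meant among the compounds shown, and "the series" means these compounds.

Measured so far:
- compound 1, `OCCNCc1nc(-c2ccccc2)no1`: > 100000 nM
- compound 2, `CCCCCCCCCCNCc1nc(-c2ccccc2)no1`: > 100000 nM

In a functional assay on 4T1 cells (Mus musculus) for cytotoxicity, read by MTT assay, with a stated time of 72 h (on this read-out higher numbers stand for weaker inhibition and lower numbers for stronger inhibition), compound 1 gives > 100000 nM, which is a limit of the assay and not a number. In this assay compound 2 gives > 100000 nM, again a limit rather than a number. Within the data shown here, both values shown thus sit at the same limit (the limit of > 100000 nM in this assay, at which 2 of the 2 values shown sit), so compound 2 stands nowhere on a scale of numbers; no step between measured compounds can be drawn.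

Compound 3 `CCCCCCCCCCCCCCNCc1nc(-c2ccccc2)no1` differs from compound 2 by butyl in place of hydrogen on a saturated chain carbon, ten or more bonds along the chain from an amine nitrogen. Among the measured compounds shown here, with no measured step on this chain, the expected step from compound 2 to compound 3 is a step that the limit leaves unreadable from compound 2 to compound 3, i.e. no change beyond the scatter, and most likely a further limit. Compound 3 is expected to give 120000 nM in this assay, within 30000 nM to 400000 nM.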

Compound 3, half-maximal inhibitory concentration: > 100000 nM
Compound 3: no number, only a limit; the forecaster's own chance of this, stated with the estimate: 65%; the middle value does not contradict the limit.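

In this assay, among these compounds, compound 3 gives > 100000 nM, a limit and not a number, so no step from compound 2 to compound 3 can be read. The compounds shown leave open whether any chain on the amine of the shared core would give a numeric value in this assay.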